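A few compounds are considered here, and "the series" means these few. Any claim that something is new, unique, unknown or untested is made for them only; others in the source may bear on it.

Working notes on the series, read in a functional assay on CCRF-CEM cells (Homo sapiens) for cytotoxicity, in the absence of a further agent; on this read-out higher numbers stand for weaker inhibition and lower numbers for stronger inhibition. Compound 2 `Nc1nc(N)c(CCCN(Cc2ccc(NC(CCC(=O)O)C(=O)O)cc2)c2ccc([N+](=O)[O-])c(F)c2F)c(O)n1` gives > 100000 nM, which is a limit of the assay and not a number. Compound 1 `COC(=O)c1ccc(CN(CCCc2c(N)nc(N)nc2O)c2cc(F)cc(F)c2[N+](=O)[O-])cc1` gives > 100000 nM, which is also a limit. Compound 2 therefore has no numerical position in the series, and the only data are the limit of > 100000 nM in this assay, at which 2 of the 2 values shown sit.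

Compound 3 `COC(=O)c1ccc(CN(CCCc2c(N)nc(N)nc2O)c2ccc([N+](=O)[O-])c(F)c2F)cc1` has methoxycarbonyl in place of (1,3-dicarboxypropyl)amino on an aromatic carbon, para to a large group: methoxycarbonyl in place of (1,3-dicarboxypropyl)amino on an aromatic carbon. Compound 3 carries methoxycarbonyl, as does compound 1, although the two cores differ. A similar reading is expected from compound 3 on the evidence of compound 1, whose limit is > 100000 nM.

No measured step sizes this change, so no shift beyond the scatter is expected in this assay. The estimated change is a number no higher from compound 2 to compound 3 (the limit leaves the size open). If a number is obtained rather than a limit, it would have to indicate stronger inhibition than either limit shows. The estimated value for compound 3 is 100000 nM, with an expected range of 30000 nM to 200000 nM.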

Compound 3, half-maximal inhibitory concentration: 45000 nM
For compound 3 the middle estimate is 2.2-fold (0.35 log units) above the measured one; low and high end bracket the measured number.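

Within the data shown here, two single changes now lead out of the limit in this assay, and both end at the first number: methoxycarbonyl in place of (1,3-dicarboxypropyl)amino on an aromatic carbon, para to a large group, gives an at least 2.2-fold lower number from compound 2 to compound 3 (0.34 log units; beyond the scatter). With methoxycarbonyl held constant, 2,3-difluoro-4-nitrophenyl in place of 3,5-difluoro-2-nitrophenyl on an amine nitrogen gives an at least 2.2-fold lower number from compound 1 to compound 3 (0.34 log units; beyond the scatter), so both this substituent and the aryl group on the amine nitrogen bear on the reading, which the two limits alone could not show. Both steps start from a limit, so each gives only a lower bound on the size of the change and the two cannot be ranked against each other: the limit of > 100000 nM in this assay, at which 2 of the 3 values shown sit.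

How much of the step from the (1,3-dicarboxypropyl)amino compound belongs to methoxycarbonyl itself stays open, since the compounds shown do not tell what an amide, a nitrile or a plain carboxylic acid would read at the same aromatic carbon. Also open, on these data alone, is whether the reading of compound 3 holds with a chain longer than the one joining the shared core to the amine nitrogen.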